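The compounds below may be only part of what the source reports. "The series", "measured", "known", "first", "only" and "open" are said of these compounds alone.

Of the compounds shown here, three with a shared core have been tested in an assay on isolated protein for inhibition of 2-Hydroxyacid oxidase 2 (Homo sapiens), tested at 1 uM; on this read-out higher numbers stand for a stronger effect at the one concentration tested and lower numbers for a weaker effect. Compound 1, with the structure `Cc1n[nH]c(C(=O)O)c1Cc1cccc(-c2cccc(F)c2)c1`, gives 20% in this assay. Compound 2, with the structure `Cc1c(Cc2cccc(-c3ccc(F)cc3)c2)c(C(=O)O)nn1C`, gives 2%, and compound 3, with the structure `Cc1n[nH]c(C(=O)O)c1Cc1ccccc1-c1ccc(F)cc1`, gives 11%. Among these three numbers compound 1 stands highest; the gap to compound 3 lies within the usual scatter of the assay, so the two cannot be told apart, while the gap to compound 2 lies beyond it.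

The next compound, compound 4, with the structure `Cc1n[nH]c(C(=O)O)c1Cc1cccc(OC(F)(F)F)c1`, has not been measured in this assay. It differs from compound 1 in one place: trifluoromethoxy in place of 3-fluorophenyl on an aromatic carbon. A whole aromatic ring leaves and a much smaller group enters in its stead. Going by the values given here, nothing measured so far shows what such a change does in this assay. Compound 4 is therefore expected to give 12%, within a range from 0% to 28%. The expected step of a number 8 percentage points lower from compound 1 to compound 4 (within the scatter) is a small drop, most likely not beyond the scatter.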

Compound 4, a percentage reported as inhibition, at one concentration (the size of the read-out at that concentration, not a potency): 2%
Compound 4: middle estimate off by 10 percentage points, on the high side; measured number inside the range.
By their numbers in this assay, from the lowest: compounds 2, 4, 3 and 1 (each within the scatter of the next, the first and the last beyond it).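

In this assay, trifluoromethoxy in place of 3-fluorophenyl on this aromatic carbon gives a number 18 percentage points lower from compound 1 to compound 4 (beyond the scatter). Going by these compounds alone, this is the first change in a single place that can be read, and it shows that the group at this position affects the read-out: here, the second aromatic ring cannot be exchanged for this smaller group without a loss. No data at hand say why the number falls.

One exchange cannot separate the loss of the ring from the particular properties of the group that replaces it, and it cannot show how other groups would behave here. A plain phenyl ring without fluorine, a pyridine ring or a methoxy group on the same aromatic carbon would help tell these possibilities apart.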